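This account rests on a few compounds, and the source may have more. Where it says the series, first, only, none or still open, it means among the compounds named here.

Going by the values given here, compound 2 `Cc1cccc(NC(=O)c2cccc(C#N)c2)n1` gives the lower of the two numbers so far in an assay on membranes from brain for binding affinity to metabotropic glutamate receptor 5 (Rattus norvegicus); on this read-out higher numbers stand for weaker inhibition and lower numbers for stronger inhibition: compound 2 gives 330 nM, while compound 1 `Cc1cccc(NC(=O)c2cccc(C(F)(F)F)c2)n1` gives 18700 nM in this assay. Among the compounds with values here, the one measured step between them, a 57-fold lower number from compound 1 to compound 2 (1.75 log units; beyond the scatter), shows how strongly this assay responds to what sits at that position of the benzamide ring. Compound 3 `Cc1cccc(NC(=O)c2cccc(OCc3ccccc3)c2)n1` carries benzyloxy in place of cyano on an aromatic carbon. Within the data shown here, no measured step involves a benzyloxy group, so the only step that bears on the change is the large one from compound 1 to compound 2, which shows that this position is sensitive to exchange. Given that sensitivity and the absence of any direct precedent, the step is expected to go toward a higher number, estimated as a 15-fold higher number from compound 2 to compound 3 (1.18 log units; beyond the scatter) in this assay. Compound 3 is accordingly expected to give about 5000 nM, with a likely range from 800 nM to 30000 nM.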

Compound 3, half-maximal inhibitory concentration: 33000 nM
Compound 3: middle estimate off by 6.6-fold (0.82 log units), on the low side; the whole stated range lies below it.
By their numbers in this assay, from the lowest: compound 2; then compounds 1 and 3 (each within the scatter of the next).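

In this assay, benzyloxy and trifluoromethyl cannot be told apart at this position, with a 1.8-fold higher number from compound 1 to compound 3 (0.25 log units; within the scatter) even though benzyloxy brings 8 heavy atoms and a six-membered aromatic ring of carbon only. Of the three groups, cyano alone gives the low number, and the exchange for benzyloxy shows a 100-fold higher number from compound 2 to compound 3 (2.00 log units; beyond the scatter) as a step of about the same size as the earlier one, so the response is no longer tied to trifluoromethyl alone. No measurement here explains why cyano stands apart from the other two groups.

The compounds shown leave open whether a methoxy group, a chlorine atom or an amine at this place would fall near compound 2 or near compounds 1 and 3. Cyano is seen on one core only, so whether its advantage carries over to other cores also remains open.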